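Swapping a Methyl Aryl Ether for an Ethyl One

This account rests on a few compounds, and the source may have more. Where it says the series, first, only, none or still open, it means among the compounds named here.

Compound 1 `Cc1ccc(OC2CCN(c3ccc(-n4ccnc4)nn3)CC2)cc1` carries a 4-methylphenyl group on the oxygen of its shared core. Within the data shown here, in an assay on microsomes from liver for inhibition of acyl-CoA desaturase 1 (Rattus norvegicus) (a higher number here means a weaker inhibitor, a lower number a stronger inhibitor), compound 1 gives 527 nM, one of only two numbers measured so far, and the other lies within the usual scatter of it. That other compound is compound 2 `FC(F)(F)c1ccc(OC2CCN(c3ccc(-n4ccnc4)nn3)CC2)cc1`, in which a trifluoromethyl stands in place of the methyl on the aromatic carbon; in this assay compound 2 gives 371 nM. The step of a 1.4-fold lower number from compound 1 to compound 2 (0.15 log units; within the scatter) shows that exchanging one small group for another on this aryl ring left the reading within the scatter.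

Compound 3 `CCc1cccc(OC2CCN(c3ccc(-n4ccnc4)nn3)CC2)c1` has not yet been measured. Its change from compound 1 is 3-ethylphenyl in place of 4-methylphenyl on an oxygen on a saturated carbon. Among the measured compounds shown here, no measured step covers this particular exchange, so the only guide is the small step from compound 1 to compound 2. The expected step is therefore a 1.1-fold lower number from compound 1 to compound 3 (0.02 log units; within the scatter), nothing beyond the scatter. Compound 3 is expected to give about 500 nM in this assay, with an estimated range from 200 nM to 1300 nM.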

Compound 3, half-maximal inhibitory concentration: 38 nM
The estimate for compound 3 lay 13-fold (1.12 log units) above the measured number; measured number outside the range, below it.
By their numbers in this assay, from the lowest: compound 3; then compounds 2 and 1 (each within the scatter of the next).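

The aryl group on the oxygen of the shared core is not a place where every exchange has little effect. In this assay, 3-ethylphenyl in place of 4-methylphenyl gives a 14-fold lower number from compound 1 to compound 3 (1.14 log units; beyond the scatter), a large step, whereas trifluoromethyl in place of methyl gave only a 1.4-fold lower number from compound 1 to compound 2 (0.15 log units; within the scatter), which stays within the scatter. This single exchange changes two things at once, ethyl for methyl and the ring number in the group's name, 3 for 4, and no information at hand explains why the step is so large.

The compounds shown leave open how much of the step belongs to the ethyl group and how much to the different ring number, since the two changes arrive together in compound 3. They also leave open what happens when the ethyl of 3-ethylphenyl gives way to a longer chain such as propyl, or to a different kind of group such as an amine or a carboxylic acid.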